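A few compounds are considered here, and "the series" means these few. Any claim that something is new, unique, unknown or untested is made for them only; others in the source may bear on it.

Compound 1 `O=c1c2ccccc2c(Nc2n[nH]c3ccccc23)nn1-c1ccccc1` and compound 2 `COc1ccc(Cn2nc(Nc3cc(C)[nH]n3)c3ccccc3c2=O)cc1` are built on the same core. In a functional assay on MCF7 cells (Homo sapiens) for cytotoxicity (a lower number here means a stronger inhibitor, a higher number a weaker inhibitor), compound 1 gives "not determined" (no result reported), so no number stands against it. In this assay compound 2 gives > 30000 nM, which is a limit of the assay and not a measured number. What the two entries show is the limit of > 30000 nM in this assay, at which 1 of the 2 values shown sits. Compound 3 `Cc1cc(Nc2nn(Cc3csc(C)n3)c(=O)c3ccccc23)n[nH]1` has not yet been measured. It differs from compound 2 in one place: 2-methyl-1,3-thiazol-4-yl in place of 4-methoxyphenyl on a saturated chain carbon bound to an aromatic nitrogen. Among the measured compounds shown here, no measured step between two compounds of this kind exists here, so the size of the change in this assay cannot be read off a neighbour. Because compound 2 stands at the limit of > 30000 nM in this assay, at which 1 of the 2 values shown sits, the step is expected to fall within the scatter or to stay unresolved, at about a number no higher from compound 2 to compound 3 (the limit leaves the size open). Compound 3 is therefore expected to give roughly 30000 nM, in a range from 10000 nM to 100000 nM.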

Compound 3, half-maximal inhibitory concentration: > 30000 nM
Compound 3 ended at the assay's limit (the forecaster's own chance of this, stated with the estimate: 70%); the middle value lies on the limit itself.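

No step can be read from compound 2 to compound 3, as both end at a limit and not at a number: the limit of > 30000 nM in this assay, at which 2 of the 3 values shown sit.

The compounds shown leave open whether 2-methyl-1,3-thiazol-4-yl in place of 4-methoxyphenyl changes anything in this assay.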